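Swapping the Outer Aryl Ring: Cytotoxicity Stays Unchanged

A few compounds are considered here, and "the series" means these few. Any claim that something is new, unique, unknown or untested is made for them only; others in the source may bear on it.

Three compounds share one core and differ only in the aromatic ring attached to it. Compound 1, `CCOC(=O)CCCCCOc1cccc(CN(C(=O)c2ccc(-c3cccc4ccccc34)cc2)C(C)C)c1`, carries a naphthalen-1-yl group; compound 2, `CCOC(=O)CCCCCOc1cccc(CN(C(=O)c2ccc(-c3cccnc3)cc2)C(C)C)c1`, a pyridin-3-yl group; compound 3, `CCOC(=O)CCCCCOc1cccc(CN(C(=O)c2ccc(-c3cccc(C(C)=O)c3)cc2)C(C)C)c1`, a 3-acetylphenyl group. In an ADME assay on Raji cells (Homo sapiens) for cytotoxicity, read by CellTiter-Glo and resazurin assay, with a stated time of 72 h (a higher number here means that more compound is needed for the effect, a lower number that less compound is needed), compound 1 gives > 26000 nM, which is a limit of the assay rather than a number. Compound 2 likewise gives only a limit, > 26000 nM. Compound 3 too gives only a limit, > 26000 nM. Because all three values sit at the limit of > 26000 nM in this assay, at which 3 of the 3 values shown sit, the steps between them cannot be sized: a step that the two limits leave unreadable from compound 1 to compound 2, a step that the two limits leave unreadable from compound 1 to compound 3 and a step that the two limits leave unreadable from compound 2 to compound 3 all remain unreadable.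

Compound 4, `CCOC(=O)CCCCCOc1cccc(CN(C(=O)c2ccc(-c3cccc(OCC(C)C)c3)cc2)C(C)C)c1`, is the next change: isobutoxy in place of acetyl on an aromatic carbon. Among the measured compounds shown here, no measured step tells how the outer ring affects this assay; every value so far is a limit. Three different rings all stayed at that limit, and compound 4 is expected to do the same, with an estimate of 40000 nM and a range from 15000 nM to 110000 nM. The step that the limit leaves unreadable from compound 3 to compound 4 is accordingly expected to stay within the scatter, most likely reported once more as a limit rather than a number.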

Compound 4, half-maximal effective concentration: > 26000 nM
Compound 4: a limit, no number; the forecaster's own chance of this, stated with the estimate: 85%; the middle value lies beyond the limit too.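

In this assay compound 4 gives > 26000 nM, which is a limit and not a number. No step between compound 4 and compound 1, compound 2 or compound 3 can be read, because all four compounds end at the same limit: the limit of > 26000 nM in this assay, at which 4 of the 4 values shown sit.

The compounds shown leave open whether any outer ring on the shared core gives a measurable value in this assay.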